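Swapping 3-nitrophenyl for 4-methoxyphenyl on the shared core

The source may report more compounds than this note shows. Statements on the series, on what has been measured and on what is new or still open speak of the compounds shown alone.

In a functional assay on A549 cells (Homo sapiens) for antiproliferative activity, read by MTT assay, with a stated time of 72 h (on this read-out higher numbers stand for weaker inhibition and lower numbers for stronger inhibition), three compounds built on one core have been measured. Compound 1 `COc1ccc(-c2ccc3ncn(-c4cc(OC)c(OC)c(OC)c4)c3c2)cc1F` gives 1430 nM, compound 2 `COc1cc(-n2cnc3ccc(-c4cc(F)ccc4F)cc32)cc(OC)c1OC` gives 7940 nM, and compound 3 `COc1cc(-n2cnc3ccc(-c4cccc([N+](=O)[O-])c4)cc32)cc(OC)c1OC` gives 5410 nM. Compound 3 sits toward the high end of these numbers, with a 1.5-fold lower number from compound 2 to compound 3 (0.17 log units; within the scatter) and a 3.8-fold higher number from compound 1 to compound 3 (0.58 log units; beyond the scatter).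

The next compound, compound 4 `COc1ccc(-c2ccc3ncn(-c4cc(OC)c(OC)c(OC)c4)c3c2)cc1`, carries 4-methoxyphenyl in place of 3-nitrophenyl on an aromatic carbon. The most relevant measured compound is compound 1, whose 3-fluoro-4-methoxyphenyl group is the closest match to the entering group. The step to compound 3 already given therefore bears most directly, and the other modest step from that compound, a 5.6-fold higher number from compound 1 to compound 2 (0.74 log units; beyond the scatter), points the same way. A step of similar size in the opposite direction is thus expected in this assay, with the estimate being a 3.4-fold lower number from compound 3 to compound 4 (0.53 log units; beyond the scatter). The expected value for compound 4 is 1600 nM, with an estimated range of 500 nM to 5000 nM.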

Compound 4, half-maximal inhibitory concentration: > 10000 nM
Compound 4: only a limit was reported (the forecaster's own chance of this, stated with the estimate: 3%); at least 6.2-fold (0.79 log units) between middle value and limit.
By their numbers in this assay, from the lowest: compound 1; then compounds 3 and 2 (each within the scatter of the next). At a limit, above all of these: compound 4.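

In this assay compound 4 gives > 10000 nM, which is a limit and not a number: the limit of > 10000 nM in this assay, at which 1 of the 4 values shown sits.

Even so, the one-place change of hydrogen in place of fluoro can be read, with an at least 6.9-fold higher number from compound 1 to compound 4 (0.84 log units; beyond the scatter), so the 4-methoxyphenyl group alone does not keep the number of compound 1, and the fluoro of the 3-fluoro-4-methoxyphenyl group matters at this position. The other two steps are floors only, an at least 1.8-fold higher number from compound 3 to compound 4 (0.26 log units; that floor lies within the scatter) and an at least 1.2-fold higher number from compound 2 to compound 4 (0.10 log units; that floor lies within the scatter), and they show no more than that 4-methoxyphenyl does no better here than 3-nitrophenyl or 2,5-difluorophenyl.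

On these data alone, the true size of all three steps stays open. So does the question of whether chloro, hydroxyl or an amine in place of that fluoro would keep the number of compound 1.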